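This account rests on a few compounds, and the source may have more. Where it says the series, first, only, none or still open, it means among the compounds named here.

Measured in an assay on isolated protein for inhibition of alpha-mannosidase (Canavalia ensiformis), tested at 1000 uM; on this read-out lower numbers stand for less inhibition and higher numbers for more inhibition at the one concentration tested (going by the name of the read-out): compound 1 `OC[C@]1(c2ccc(F)cc2)NC[C@H](O)[C@H]1O` gives 6.6%; compound 2 `OC[C@@]1(c2cccc(F)c2)NC[C@@H](O)[C@@H]1O` gives 0%; compound 3 `OC[C@@]1(c2ccc(F)cc2)NC[C@@H](O)[C@@H]1O` gives 6.6%.

Among the compounds with values here, compound 1 sits level with compound 3, and compound 2 lies within the scatter of both, so no compound can be ranked against another. The step of no change at the digits printed from compound 1 to compound 3 (within the scatter) is consistent with the fact that compounds 1 and 3 differ only in the configuration as drawn. Compound 4 `OC[C@]1(c2ccc(O)cc2)NC[C@H](O)[C@H]1O` differs from compound 1 by hydroxy in place of fluoro on an aromatic carbon. Within the data shown here, no measured step concerns a substituent on the aromatic ring; the only measured step is a change of configuration. Compound 1 gives 6.6%, near the bottom of the read-out, as do the other two. Compound 4 is therefore expected to stay low, with an estimated step of a number 1.6 percentage points lower from compound 1 to compound 4 (within the scatter) within the scatter. Compound 4 is estimated at 5%, range 0% to 15%.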

Compound 4, a percentage reported as inhibition, at one concentration (the size of the read-out at that concentration, not a potency): 3.4%
Beside the measured number, compound 4's estimate is 1.6 percentage points above it; the range from low to high includes it.
By their numbers in this assay, from the lowest: compounds 2, 4, 1 and 3 (each within the scatter of the next).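

Within the data shown here, at this aromatic carbon, hydroxy in place of fluoro gives a number 3.2 percentage points lower from compound 1 to compound 4 (within the scatter) in this assay, the only measured step at a ring substituent. A group with a hydrogen-bond donor and acceptor thus enters here without moving the read-out beyond the scatter, and compound 4 stays low at 3.4%. Nothing at hand bears on the reason for this outcome.

Going by these compounds, whether an amine, a carboxylic acid or a longer chain at this aromatic carbon would lift the read-out remains open. Also open, on these data alone, is whether the mirror image of compound 4 would stay level with compound 4, as compound 3 does with compound 1.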